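Butoxy in place of trifluoromethyl: compound 4 outlook

A few compounds are considered here, and "the series" means these few. Any claim that something is new, unique, unknown or untested is made for them only; others in the source may bear on it.

Measured compounds in a functional assay on CHO-K1 cells for antagonist activity at transient receptor potential cation channel subfamily V member 1 (Homo sapiens), read by FLIPR; a higher number here means a weaker inhibitor, a lower number a stronger inhibitor:
- compound 1 `CC(C(=O)NCc1ccc(C(F)(F)F)nc1NC1CCCCC1)c1ccc(NS(C)(=O)=O)c(F)c1` gives 20.4 nM
- compound 2 `CC(C(=O)NCc1ccc(C(F)(F)F)nc1Nc1ccc(F)cc1)c1ccc(NS(C)(=O)=O)c(F)c1` gives 39.2 nM
- compound 3 `CC(C(=O)NCc1ccc(C(F)(F)F)nc1N1CCC(C(F)(F)F)CC1)c1ccc(NS(C)(=O)=O)c(F)c1` gives 0.6 nM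

Compound 3 holds the lowest number of the three. Its separation from the others is beyond the scatter in both cases: a 34-fold lower number from compound 1 to compound 3 (1.53 log units; beyond the scatter) and a 65-fold lower number from compound 2 to compound 3 (1.82 log units; beyond the scatter). The remaining measured step, a 1.9-fold higher number from compound 1 to compound 2 (0.28 log units; within the scatter), is within the scatter.

Compound 4 `CCCCOC1CCN(c2nc(C(F)(F)F)ccc2CNC(=O)C(C)c2ccc(NS(C)(=O)=O)c(F)c2)CC1` differs from compound 3 by butoxy in place of trifluoromethyl on a saturated ring carbon. Going by the values given here, no measured step touches this position: both large steps exchange the whole group on the aromatic carbon, and the small one exchanges cyclohexyl for 4-fluorophenyl on a ring nitrogen. The data therefore give no direct guide. As the group on the aromatic carbon of compound 3 is kept and only its substituent changes, a step smaller than the large measured ones is expected in this assay, most likely a modest move toward a higher number, possibly within the scatter.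

Compound 4 is expected to give 2 nM, with a range of 0.4 nM to 10 nM. The expected step is a 3.3-fold higher number from compound 3 to compound 4 (0.52 log units; beyond the scatter).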

Compound 4, inhibition constant: 3.5 nM
The estimate for compound 4 lay 1.8-fold (0.24 log units) below the measured number; low and high end bracket the measured number.
By their numbers in this assay, from the lowest: compound 3; then compound 4; then compounds 1 and 2 (each within the scatter of the next).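

In this assay, going by these compounds alone, this is the first change on the saturated ring carbon three ring bonds from the ring nitrogen, and replacing trifluoromethyl with butoxy gives a 5.8-fold higher number from compound 3 to compound 4 (0.77 log units; beyond the scatter). The position therefore affects the read-out, yet butoxy still preserves much of the advantage of the ring-nitrogen attachment on the aromatic carbon, with an 11-fold lower number from compound 2 to compound 4 (1.05 log units; beyond the scatter) and a 5.8-fold lower number from compound 1 to compound 4 (0.77 log units; beyond the scatter), so that advantage does not depend on trifluoromethyl alone. No supporting evidence bears on the origin of the step from trifluoromethyl to butoxy.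

With only two substituents shown at this carbon, the compounds do not separate the effect of the ether oxygen from that of the chain. Methoxy, a plain pentyl chain, a hydroxyl or a primary amine at the same carbon would show whether the number tracks chain length, the oxygen or neither.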